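Replacing an indole with a pyrrolidine on a shared amide

The source may report more compounds than this note shows. Statements on the series, on what has been measured and on what is new or still open speak of the compounds shown alone.

Compound 1 `CCn1nc(C)cc1C(=O)Nc1nc2cc(C(N)=O)cc(OC)c2n1CCCNC(=O)OCc1ccccc1` and compound 2 `COc1cc(C(N)=O)cc2nc(NC(=O)c3cc4ccccc4n3C)n(CCCNC(=O)OCc3ccccc3)c12` share one core and differ only in the group attached to the carbonyl carbon of the amide. In an assay for activation of interferon regulatory factor 3 (Homo sapiens), read by a luciferase reporter, with a stated time of 20 h (a lower number here means that less compound is needed, a higher number that more compound is needed for the effect), compound 1 gives a limit of the assay, > 100000 nM. In this assay compound 2 likewise gives a limit of the assay, > 100000 nM. The step that the two limits leave unreadable from compound 1 to compound 2 cannot be read, since both values sit at the limit of > 100000 nM in this assay, at which 2 of the 2 values shown sit. Compound 3 `COc1cc(C(N)=O)cc2nc(NC(=O)C3CCCN3C)n(CCCNC(=O)OCc3ccccc3)c12` changes the same carbonyl carbon once more: 1-methylpyrrolidin-2-yl in place of 1-methyl-1H-indol-2-yl on a carbonyl carbon. Going by the values given here, no measured step with a readable size bears on this change; the only comparison, from compound 1 to compound 2, is unreadable. Compound 3 is therefore expected to remain at the same limit, and the step that the limit leaves unreadable from compound 2 to compound 3 is expected to be too small to read. Compound 3 is estimated at 150000 nM in this assay, with a range from 30000 nM to 1000000 nM.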

Compound 3, half-maximal effective concentration: > 100000 nM
Compound 3 gave a limit, no number (the forecaster's own chance of this, stated with the estimate: 85%); the middle value lies beyond the limit too.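

Compound 3, like compound 1 and compound 2, gives only a limit in this assay, so no step among these compounds can be read: the limit of > 100000 nM in this assay, at which 3 of the 3 values shown sit.

The compounds shown leave open which group on the carbonyl carbon, if any, would give a measurable value.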